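Low toxicity at the assay limit, and one methyl removed

The source may report more compounds than this note shows. Statements on the series, on what has been measured and on what is new or still open speak of the compounds shown alone.

Compound 1 `Cc1ccccc1C(=O)Nc1ncc(-c2ccccc2)n1C` gives > 100000 nM as a limit
Compound 2 `Cn1cc(-c2ccccc2)nc1NC(=O)c1ccc(F)cc1` gives > 50000 nM as a limit
Compound 3 `COc1ccc(-c2cnc(NC(=O)c3ccc(O)cc3)n2C)cc1` gives > 100000 nM as a limit

These results come from a toxicity assay on THP-1 cells (Homo sapiens) for inhibition (on this read-out lower numbers stand for higher toxicity in this test and higher numbers for lower toxicity in this test), and each is a limit of the assay, not a number. Compound 1 stands at the limit of > 100000 nM in this assay, at which 2 of the 3 values shown sit, as a limit, so it has no exact value. Compound 2 stands at the limit of > 50000 nM in this assay, at which 1 of the 3 values shown sits, as a limit.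

Compound 4 `Cn1c(-c2ccccc2)cnc1NC(=O)c1ccccc1` has not yet been measured in this assay and has hydrogen in place of methyl on an aromatic carbon, which turns 2-methylphenyl into phenyl hydrogen in place of methyl on an aromatic carbon in the step from compound 1.

Among the measured compounds shown here, no measured step between two compounds is available as a guide. The expectation rests on compound 1, with > 100000 nM as its limit. It also rests on compound 3, with > 100000 nM as its limit. The estimated change is a number no higher from compound 1 to compound 4 (the limit leaves the size open) in this assay with no step beyond the scatter expected in either direction. For compound 4 the estimated value is 100000 nM with an expected range from 50000 nM to 200000 nM and the outcome is expected to be only a limit of the assay.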

Compound 4, half-maximal cytotoxic concentration: > 100000 nM
Compound 4: a limit, no number; the forecaster's own chance of this, stated with the estimate: 90%; the middle value sits exactly at the limit.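

In this assay, compound 1 and compound 4 are both known only as limits, and no step can be read between them. The compounds shown leave open whether going from 2-methylphenyl to phenyl changes toxicity at all, and at what concentration any of them becomes toxic.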